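A few compounds are considered here, and "the series" means these few. Any claim that something is new, unique, unknown or untested is made for them only; others in the source may bear on it.

Compound 3 `O=C(Nc1ccc(Oc2ccnc3[nH]ccc23)c(F)c1)c1nn(-c2ccc(Br)cc2)ccc1=O` gives 68000 nM in a functional assay on HepG2 cells (Homo sapiens) for cytotoxicity, read by MTT assay, with a stated time of 72 h (a lower number here means a stronger inhibitor, a higher number a weaker inhibitor), the highest of the two numbers shown here. Compound 1 `O=C(Nc1ccc(Oc2ccnc3[nH]ccc23)cc1)c1nn(-c2ccc(Br)cc2F)ccc1=O` gives 46400 nM in this assay, a reading within the scatter of compound 3. Compound 2 `COc1ccc(-n2ccc(=O)c(C(=O)Nc3ccc(Oc4ccnc5[nH]ccc45)c(F)c3)n2)cc1` reaches only the limit > 60000 nM in this assay, a limit and not a number (the limit of > 60000 nM in this assay, at which 1 of the 3 values shown sits). The step from compound 2 to compound 3, a step that the limit leaves unreadable from compound 2 to compound 3, stays unreadable for that reason. Compound 4 `O=C(Nc1ccc(Oc2ccnc3[nH]ccc23)c(F)c1)c1nn(-c2ccc(Br)cc2F)ccc1=O` differs from compound 3 by fluoro in place of hydrogen on an aromatic carbon. Going by the values given here, no measured step isolates this change; compound 1 carries the same 4-bromo-2-fluorophenyl group with a differently substituted core, and its number lies within the scatter of compound 3. The expected step of a 1.1-fold lower number from compound 3 to compound 4 (0.05 log units; within the scatter) in this assay for compound 4 is none beyond the scatter. Compound 4 is estimated at 60000 nM in this assay, range 25000 nM to 150000 nM.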

Compound 4, half-maximal inhibitory concentration: 56500 nM
Beside the measured number, compound 4's estimate is 1.1-fold (0.03 log units) above it, and the stated range covers the measured number.
By their numbers in this assay, from the lowest: compounds 1, 4 and 3 (each within the scatter of the next).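

Fluoro on this aromatic carbon, ortho to a large group, now has a measured step in this assay: a 1.2-fold lower number from compound 3 to compound 4 (0.08 log units; within the scatter). Fluoro entering on an aromatic carbon of the shared core also has one: a 1.2-fold higher number from compound 1 to compound 4 (0.09 log units; within the scatter). Measured against a limit and not a number, 4-bromo-2-fluorophenyl in place of 4-methoxyphenyl yields only a floor: an at least 1.0-fold lower number from compound 2 to compound 4 (0.02 log units; that floor lies within the scatter).

Going by these compounds, whether an amine or a carboxylic acid on this aromatic ring would move the number beyond the scatter remains open. The same question stands for chloro or methyl at this position.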